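The source may hold more compounds than are shown below. What is called first, only, known or untested is meant among the compounds shown, and "the series" means these compounds.

Compound 1 `CC(C)CCN(C)Cc1ccc(C2=CCCN(C)C2)cc1` reads > 50000 nM
Compound 2 `CC(C)CN(C)Cc1ccc(C2CCCN(C)C2)cc1` reads > 50000 nM

Both readings come from an ADME assay on HL-60 cells (Homo sapiens) for cytotoxicity, read by MTT assay, with a stated time of 24 h; a higher number here means a weaker inhibitor, a lower number a stronger inhibitor. Compound 2 stands at > 50000 nM as a limit of the assay, not as a number. Compound 1 gives > 50000 nM as a limit too. Among the measured compounds shown here, the series so far therefore comes down to one reading, (the limit of > 50000 nM in this assay, at which 2 of the 2 values shown sit), and no exact value is available for either compound.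

Compound 3 `CC(C)CCN(C)Cc1ccc(C2CCCN(C)C2)cc1` differs from compound 2 in one place (isobutyl in place of isopropyl on a saturated chain carbon bound to an amine nitrogen), with isobutyl in place of isopropyl on a saturated chain carbon bound to an amine nitrogen. Cut one bond further out, the same difference reads isobutyl to isopentyl. For the measured compounds named here, no measured pair shows the size of this change.

Compound 1 carries isopentyl(methyl)amino on its own core and still reads > 50000 nM as a limit, so little change is expected. In this assay the expected step is a number no higher from compound 2 to compound 3 (the limit leaves the size open), which means none beyond the usual scatter and no favoured direction. For compound 3 the estimated value is 50000 nM, within an expected range from 25000 nM to 100000 nM, and another limit reading is likely.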

Compound 3, half-maximal inhibitory concentration: > 50000 nM
Compound 3 gave a limit, no number; the forecaster's own chance of this, stated with the estimate: 85%; the middle value sits exactly at the limit.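

No step can be read from compound 2 to compound 3 or from compound 1 to compound 3 in this assay, because each reading is a limit and not a number: the limit of > 50000 nM in this assay, at which 3 of the 3 values shown sit.

The compounds shown leave open whether any of them has an exact value in this assay, and so what isobutyl in place of isopropyl changes there.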